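Removing a Hydroxy Group: Effect on Lipoxygenase Inhibition

The compounds below may be only part of what the source reports. "The series", "measured", "known", "first", "only" and "open" are said of these compounds alone.

Compound 1 `COc1cc(/C=C/C=C/C(=O)N2CCCCC2)cc(OC)c1O` gives 32.7% in an assay for inhibition of Polyunsaturated fatty acid 5-lipoxygenase (Homo sapiens), read by spectrophotometry, tested at 20 uM; a lower number here means less inhibition, a higher number more inhibition at the concentration tested (going by the name of the read-out).
Compound 2 `O=C(/C=C/C=C/c1ccc(O)cc1)N1CCCCC1` gives 44.4% in this assay.
Compound 3 `O=C(/C=C/C=C/c1ccccc1)N1CCCCC1` gives 36.3% in this assay.

Compound 3 differs from compound 2 by hydrogen in place of hydroxy on an aromatic carbon; this gave a number 8.1 percentage points lower from compound 2 to compound 3 (within the scatter). Compound 4 `COc1cc(/C=C/C=C/C(=O)N2CCCCC2)cc(OC)c1` is not yet measured and differs from compound 1 by hydrogen in place of hydroxy on an aromatic carbon. The surroundings are not identical: in compound 1 the carbon is ortho to two methoxy groups (2 heavy atoms each) and para to a large group, whereas in compound 2 it is only para to a large group, so this is the same kind of change rather than the same one. The difference between the cores of compound 1 and compound 2 is not broken down here; compound 1 lies beyond the scatter below compound 2, and within the scatter of compound 3. Resting on a number 8.1 percentage points lower from compound 2 to compound 3 (within the scatter), a step of like size is expected for compound 4, a number 5.7 percentage points lower from compound 1 to compound 4 (within the scatter). In this assay compound 4 is therefore estimated at 27%, within a range from 12% to 42%.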

Compound 4, a percentage reported as inhibition, at one concentration (the size of the read-out at that concentration, not a potency): 64.9%
Beside the measured number, compound 4's estimate is 37.9 percentage points below it; measured number above the stated range.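

In this assay, putting hydrogen in place of the hydroxy group on the core of compound 1 gave a number 32.2 percentage points higher from compound 1 to compound 4 (beyond the scatter). Among the compounds shown here, the same change therefore does not carry over as a fixed step from one core to the other, and even the direction differs: the same change on two cores in this assay, a number 8.1 percentage points lower (within the scatter) from compound 2 to compound 3 and a number 32.2 percentage points higher (beyond the scatter) from compound 1 to compound 4, 40.3 percentage points apart, beyond the scatter of two such steps With only two pairs, this shows that the core matters, but it does not show which feature of the core of compound 1, such as its two methoxy groups, accounts for the gap.

The compounds shown leave open how an amine or a fluorine atom in that place would read on either core. They also leave open whether the high number of compound 4 needs both methoxy groups or would persist with only one.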